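This account rests on a few compounds, and the source may have more. Where it says the series, first, only, none or still open, it means among the compounds named here.

Measured so far:
Compound 1 `O=c1c(-c2ccc(O)cc2)coc2cc(OCCCCBr)ccc12` — in a functional assay on mitochondria (Cricetulus griseus) for inhibition of Monoamine oxidase (Homo sapiens), tested at 0.3 uM (on this read-out higher numbers stand for a stronger effect at the one concentration tested and lower numbers for a weaker effect), compound 1 gives 19.2%
Compound 2 `O=C(O)CCCCCCCCCOc1ccc2c(=O)c(-c3ccc(O)cc3)coc2c1` — compound 2 gives 74.4%

Compound 2 stands highest of the two numbers; the step of a number 55.2 percentage points higher from compound 1 to compound 2 (beyond the scatter) is the only measured one. Compound 3 `O=C(O)CCCCCCOc1ccc2c(=O)c(-c3ccc(O)cc3)coc2c1` differs from compound 2 by carboxy in place of 3-carboxypropyl on a saturated chain carbon, six bonds along the chain from an oxygen on an aromatic ring. Among the compounds with values here, the one measured step bears only loosely, since it changed both chain length and end group at once, but it ties the long carboxy-bearing chain to the higher number. Shortening the chain is therefore expected to lower the value moderately, by a number 24.4 percentage points lower from compound 2 to compound 3 (beyond the scatter), giving compound 3 an estimated 50% within 25% to 75%.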

Compound 3, a percentage reported as inhibition, at one concentration (the size of the read-out at that concentration, not a potency): 48.6%
The estimate for compound 3 lay 1.4 percentage points above the measured number; low and high end bracket the measured number.
By their numbers in this assay, from the lowest: compound 1; then compound 3; then compound 2.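

With the carboxy end kept in place, shortening the chain alone lowers the number in this assay by a number 25.8 percentage points lower from compound 2 to compound 3 (beyond the scatter) and so shows that chain length matters here, which the first step, changing length and end group together, could not separate. The shorter carboxy chain still gives a number 29.4 percentage points higher from compound 1 to compound 3 (beyond the scatter) but this step again changes both length and end group. Nothing available explains either step.

Going by these compounds, whether a still longer chain would raise the number remains open. So does whether an amine or a methyl ester at the chain end would retain it.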